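The source may report more compounds than this note shows. Statements on the series, on what has been measured and on what is new or still open speak of the compounds shown alone.

Measured in a functional assay on WM 266-4 cells (Homo sapiens) for antiproliferative activity, read by MTT assay, with a stated time of 24 h; on this read-out higher numbers stand for weaker inhibition of growth and lower numbers for stronger inhibition of growth:
compound 1 `COc1ccc(C2=NN(C(=O)c3cccnc3Cl)C(c3ccc(OCc4ccccc4)cc3)C2)cc1`, giving 9150 nM
compound 2 `Cc1ccc(C(=O)N2N=C(c3ccc(Cl)cc3)CC2c2ccc(OCc3ccccc3)cc2)c(Cl)n1`, giving 11400 nM

Among the measured compounds shown here, of these two, compound 2 and compound 1 give numbers that lie within the usual scatter of each other, so the two cannot be told apart on what has been measured, and no step between measured compounds is available to set a scale for the change at hand. Compound 3 `O=C(c1cccnc1Cl)N1N=C(c2ccc(Cl)cc2)CC1c1ccc(OCc2ccccc2)cc1` differs from compound 2 only by hydrogen in place of methyl on an aromatic carbon. A single carbon leaving from the carbonyl-bearing ring, with no ring, donor or acceptor lost, is a small change in this series, and nothing measured here points in either direction for it. The expected step from compound 2 to compound 3 is therefore a 1.1-fold lower number from compound 2 to compound 3 (0.06 log units; within the scatter), that is, none beyond the scatter. On that basis compound 3 is estimated to give 10000 nM in this assay, with a range from 4000 nM to 25000 nM.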

Compound 3, concentration for 50% growth inhibition: 7710 nM
Estimate against measurement, compound 3: 1.3-fold (0.11 log units) above; the range from low to high includes it.
By their numbers in this assay, from the lowest: compounds 3, 1 and 2 (each within the scatter of the next).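

In this assay, hydrogen in place of methyl on the aromatic carbon next to the ring nitrogen gives a 1.5-fold lower number from compound 2 to compound 3 (0.17 log units; within the scatter) and so removing this methyl produces no change that can be told from the scatter. Among the compounds shown here, the first single-place comparisons in this set are therefore both flat, as chloro in place of methoxy on an aromatic carbon, at the other end of the shared core, gives a 1.2-fold lower number from compound 1 to compound 3 (0.07 log units; within the scatter) and also stays within the scatter. Nothing available explains why either change leaves the number within the scatter.

As far as these compounds go, whether this carbon of the 2-chloropyridin-3-yl group would respond to an amine, a carboxylic acid or a longer chain remains open. The compounds shown also leave open what happens when the chloro group on that ring or the benzyloxy group is replaced.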